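Swapping the aryl group on the sulfur: fluorophenyl to dimethylphenyl

A few compounds are considered here, and "the series" means these few. Any claim that something is new, unique, unknown or untested is made for them only; others in the source may bear on it.

Measured so far in a functional assay on A549 cells (Homo sapiens) for inhibition, read by CCK-8 assay, with a stated time of 72 h, tested at 2 uM; a lower number here means less inhibition of growth, a higher number more inhibition of growth at the concentration tested:
compound 1 `COc1ccc(SCc2ccc(/C=C/C(=O)Nc3ccccc3N)cc2)cc1OC` gives 65.5%
compound 2 `Nc1ccccc1NC(=O)/C=C/c1ccc(CSc2ccc(F)cc2)cc1` gives 51.2%
compound 3 `Nc1ccccc1NC(=O)c1ccc(CSc2ccc(C(F)(F)F)cn2)cc1` gives 37.1%

Compound 2 stands second highest of the three in this assay: compound 1 lies above it beyond the scatter, and compound 3 lies below it beyond the scatter. Compound 3 differs from compound 2 in more than one place, so its value says nothing about a single change.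

Compound 4 `Cc1cc(C)cc(SCc2ccc(/C=C/C(=O)Nc3ccccc3N)cc2)c1` differs from compound 2 in one place: 3,5-dimethylphenyl in place of 4-fluorophenyl on a sulfur.

For the measured compounds named here, only one measured step touches the same sulfur: a number 14.3 percentage points lower from compound 1 to compound 2 (beyond the scatter). Going by the values given here, that step shows that the choice of aryl group on the sulfur can move the number by a modest amount, but it does not say where a 3,5-dimethylphenyl will land, since no measured compound carries one. Among the compounds with values here, with only one step to go by, the expectation for compound 4 is a small rise of a number 5.8 percentage points higher from compound 2 to compound 4 (within the scatter), inside a wide range. Compound 4 is therefore estimated at 57%, between 40% and 74%.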

Compound 4, percent growth inhibition at one concentration: 46.1%
Beside the measured number, compound 4's estimate is 10.9 percentage points above it; low and high end bracket the measured number.
By their numbers in this assay, from the lowest: compounds 3, 4 and 2 (each within the scatter of the next, the first and the last beyond it); then compound 1.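

In this assay, 3,5-dimethylphenyl in place of 4-fluorophenyl on the sulfur gives a number 5.1 percentage points lower from compound 2 to compound 4 (within the scatter), so these two aryl groups cannot be told apart at this position. Set against 3,4-dimethoxyphenyl, the same 3,5-dimethylphenyl gives a number 19.4 percentage points lower from compound 1 to compound 4 (beyond the scatter), and with the earlier step this leaves 3,4-dimethoxyphenyl with the highest number of the three aryl groups on this sulfur. No measurement shown here offers a reason for this difference.

Still open, from the compounds shown here alone, is whether compound 1 requires both of its methoxy groups, which a phenyl carrying a single methoxy group could test. Going by these compounds, it is also open how this position would respond to an aryl group carrying an amine or a carboxylic acid.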